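This account rests on a few compounds, and the source may have more. Where it says the series, first, only, none or still open, it means among the compounds named here.

Measured in a functional assay on CHO-K1 cells for antagonist activity at C-X-C chemokine receptor type 3 (Homo sapiens), read by FLIPR, with a stated time of 10 min, in the presence of a further agent that is not named here; on this read-out higher numbers stand for weaker inhibition and lower numbers for stronger inhibition:
compound 1 `Cc1nn(CC(=O)N2CCN(c3sc(C(F)(F)F)nc3-c3nc4ccccc4[nH]3)C[C@H]2C)cc1CN(C)C` gives 2.7 nM
compound 2 `Cc1nc(C)n(CC(=O)N2CCN(c3sc(C(F)(F)F)nc3-c3nc4ccc(S(C)(=O)=O)cc4[nH]3)C[C@H]2C)n1` gives 10 nM

Compound 1 holds the lowest number of the two in this assay; the number for compound 2 is higher, and that gap lies beyond the usual scatter of the read-out. Within the data shown here, no pair of measured compounds differs in a single place, so there is no measured step to lean on, and compound 2 also differs from compound 1 in more than the side group.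

Compound 3 `C[C@@H]1CN(c2sc(C(F)(F)F)nc2-c2nc3ccccc3[nH]2)CCN1C(=O)CN1CCC(F)(F)CC1` is still to be measured in this assay. Against compound 1 it shows one change: 4,4-difluoropiperidin-1-yl in place of 4-((dimethylamino)methyl)-3-methyl-1H-pyrazol-1-yl on a saturated chain carbon bound to a carbonyl carbon. Since nothing comparable has been measured, the expectation rests on compound 1 alone. The expected step is a 3.0-fold higher number from compound 1 to compound 3 (0.47 log units; beyond the scatter), a modest rise in the number, just beyond the scatter. Compound 3 is thus estimated at 8 nM, with a range from 2.5 nM to 25 nM.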

Compound 3, half-maximal inhibitory concentration: 15 nM
Compound 3: the middle estimate sits 1.9-fold (0.27 log units) below what was measured; the range from low to high includes it.
By their numbers in this assay, from the lowest: compound 1; then compounds 2 and 3 (each within the scatter of the next).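

In this assay the saturated chain carbon bound to a carbonyl carbon proves sensitive to the group it carries, but not intolerant of change: 4,4-difluoropiperidin-1-yl in place of 4-((dimethylamino)methyl)-3-methyl-1H-pyrazol-1-yl gives a 5.6-fold higher number from compound 1 to compound 3 (0.74 log units; beyond the scatter) and a modest loss of inhibition. An aromatic pyrazole is therefore not required at this place for compound 3 to reach 15 nM in the same assay. No measurement offered here accounts for the step.

The change replaces the ring, the dimethylaminomethyl arm and the fluorines together, so this single step cannot assign the loss to any one of them. A plain piperidin-1-yl, a morpholin-4-yl or a pyrazol-1-yl lacking the dimethylaminomethyl arm would be needed at this place to separate these contributions.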